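The compounds below may be only part of what the source reports. "The series", "measured", "known", "first", "only" and "open" are said of these compounds alone.

Measured compounds:
compound 1 `COc1cc(/C=C2\Cc3ccccc3/C(=C\c3ccc([N+](=O)[O-])cc3)C2=O)ccc1O` — 3800 nM
compound 2 `COc1ccc(/C=C2\Cc3ccccc3/C(=C\c3ccc([N+](=O)[O-])cc3)C2=O)cc1` — 32000 nM

In a functional assay on HSC-3 cells (Homo sapiens) for cytotoxicity (a lower number here means that less compound is tolerated, a higher number that more compound is tolerated), compound 2 gives the highest of the two numbers, with compound 1 giving a lower one, as the step of an 8.4-fold higher number from compound 1 to compound 2 (0.93 log units; beyond the scatter) shows. For the measured compounds named here, compound 3 `O=C1/C(=C/c2ccc(O)cc2)Cc2ccccc2/C1=C\c1ccc([N+](=O)[O-])cc1` differs from compound 2 by hydrogen in place of methyl on an oxygen on an aromatic ring, and this is the only change between them. Going by the values given here, the one measured step, an 8.4-fold higher number from compound 1 to compound 2 (0.93 log units; beyond the scatter), went the other way when the hydroxy was lost together with a methoxy being kept; restoring a hydroxy is therefore expected to lower the number, though no measured pair isolates this exact change. Compound 3 is expected to give 8000 nM, within 2500 nM to 30000 nM, a step of a 4.0-fold lower number from compound 2 to compound 3 (0.60 log units; beyond the scatter).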

Compound 3, half-maximal cytotoxic concentration: 14000 nM
Compound 3: the middle estimate sits 1.8-fold (0.24 log units) below what was measured; the measured number falls inside the stated range.
By their numbers in this assay, from the lowest: compound 1; then compound 3; then compound 2.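

In this assay the hydroxy now has a measured effect of its own: hydrogen in place of methyl on the oxygen gives a 2.3-fold lower number from compound 2 to compound 3 (0.36 log units; beyond the scatter) on this ring. The methoxy also counts, since hydrogen in its place gives a 3.7-fold higher number from compound 1 to compound 3 (0.57 log units; beyond the scatter) and so the hydroxy alone does not account for the lower number of compound 1. Nothing available explains either step. The compounds shown leave open whether an amine or a carboxylic acid in place of the hydroxy would lower the number further, and what a longer chain on that oxygen would do.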